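Notes on 2-carboxyphenyl in place of 4-carboxyphenyl

The source may hold more compounds than are shown below. What is called first, only, known or untested is meant among the compounds shown, and "the series" means these compounds.

- compound 1 `CC1(C)C2CCC[C@H](/C=C/c3ccccc3C(=O)O)[C@@]2(C)CC[C@@H]1O`: 380000 nM
- compound 2 `COc1ccc(CO[C@H]2CC[C@]3(C)C[C@H](Cc4ccc(C(=O)O)cc4)CCC3C2(C)C)cc1`: 200000 nM

In a functional assay on SK-MEL cells (Homo sapiens) for cytotoxicity (a higher number here means a weaker inhibitor, a lower number a stronger inhibitor), compound 2 gives 200000 nM, within the scatter of compound 1 at 380000 nM. Compound 3 `COc1ccc(CO[C@H]2CC[C@]3(C)C[C@H](Cc4ccccc4C(=O)O)CCC3C2(C)C)cc1` carries one change from compound 2: 2-carboxyphenyl in place of 4-carboxyphenyl on a saturated chain carbon bound to a saturated ring carbon. Among the measured compounds shown here, no measured pair isolates this change, so no step beyond the scatter is expected in this assay. That expectation rests only on the closeness of compound 1 at 380000 nM and compound 2 at 200000 nM. The estimated step of a 1.3-fold higher number from compound 2 to compound 3 (0.10 log units; within the scatter) stays within the scatter. For compound 3 the expected value is 250000 nM, with an estimated range of 100000 nM to 600000 nM.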

Compound 3, half-maximal inhibitory concentration: 166000 nM
Estimate against measurement, compound 3: 1.5-fold (0.18 log units) above, and the stated range covers the measured number.
By their numbers in this assay, from the lowest: compounds 3, 2 and 1 (each within the scatter of the next, the first and the last beyond it).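

In this assay, among the compounds shown here, 2-carboxyphenyl in place of 4-carboxyphenyl on a saturated chain carbon bound to a saturated ring carbon gives a 1.2-fold lower number from compound 2 to compound 3 (0.08 log units; within the scatter), the only measured pair that isolates this change. On the shared core, this assay therefore does not separate the two carboxyphenyl groups at this position. Nothing at hand explains this result.

Open, from the compounds shown here alone, is whether an amine or a primary amide in place of the carboxylic acid would give a step beyond the scatter in this assay. The same question stands for a longer chain at this position.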